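Methyl added to the ring of compound 3

The source may hold more compounds than are shown below. What is called first, only, known or untested is meant among the compounds shown, and "the series" means these compounds.

Values in a physicochemical assay for solubility, in phosphate buffer, measured as kinetic solubility, with a stated time of 24 h, at pH 6.5 (a lower number here means a less soluble compound, a higher number a more soluble compound), so far:
compound 1 `Cc1ccc(NC(=O)c2cc(Oc3ccc(S(C)(=O)=O)cc3)cc(OC(C)C)c2)nc1` gives 1400 nM
compound 2 `CC(C)Oc1cc(Oc2ccc(S(C)(=O)=O)cc2)cc(-c2cncc(=O)[nH]2)c1` gives 118000 nM
compound 3 `CC(C)Oc1cc(Oc2ccc(S(C)(=O)=O)cc2)cc(-c2nccc(=O)[nH]2)c1` gives 25000 nM

Compound 3 stands second highest of the three, under compound 2 and over compound 1. The change to compound 4 `Cc1cc(=O)[nH]c(-c2cc(Oc3ccc(S(C)(=O)=O)cc3)cc(OC(C)C)c2)n1` is methyl in place of hydrogen on an aromatic carbon next to the ring nitrogen. Going by the values given here, no measured step adds a methyl alone. The nearest guide is the modest 4.7-fold lower number from compound 2 to compound 3 (0.67 log units; beyond the scatter) between two ring variants. The large 84-fold higher number from compound 1 to compound 2 (1.93 log units; beyond the scatter) and an 18-fold higher number from compound 1 to compound 3 (1.25 log units; beyond the scatter) each replace a whole group and bear less on so small a change. No step beyond the scatter is therefore expected in this assay, and the data fix no direction. The estimated step is a 1.7-fold lower number from compound 3 to compound 4 (0.22 log units; within the scatter). For compound 4 the estimated value is 15000 nM, with an expected range from 5000 nM to 40000 nM.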

Compound 4, solubility: 15000 nM
For compound 4 middle estimate and measured number coincide at the digits printed, and the stated range covers the measured number.
By their numbers in this assay, from the lowest: compound 1; then compounds 4 and 3 (each within the scatter of the next); then compound 2.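

In this assay, methyl in place of hydrogen on an aromatic carbon next to the ring nitrogen gives a 1.7-fold lower number from compound 3 to compound 4 (0.22 log units; within the scatter) at this position. With the methyl in place, a 7.9-fold lower number from compound 2 to compound 4 (0.90 log units; beyond the scatter) and an 11-fold higher number from compound 1 to compound 4 (1.03 log units; beyond the scatter) both stay beyond the scatter, so the gaps to those two compounds hold. Nothing measured here offers an explanation for this result.
Open, going by these compounds, is whether an ethyl, an amine or a carboxylic acid on this same carbon would also stay within the scatter of compound 3. Also open, on these data alone, is whether a methyl on the ring of compound 2 would behave alike.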